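Phenyl to 4-chlorophenyl: an antiproliferative estimate

This account rests on a few compounds, and the source may have more. Where it says the series, first, only, none or still open, it means among the compounds named here.

Measured in a functional assay on HeLa cells (Homo sapiens) for antiproliferative activity, read by MTT assay, with a stated time of 72 h (on this read-out higher numbers stand for weaker inhibition and lower numbers for stronger inhibition), the three compounds read as follows:
Compound 1 `COc1ncc(-c2ccc3c(c2)N(c2ccc(C)cc2)C(=O)CO3)cc1NS(=O)(=O)c1ccc(F)cc1` gives 4650 nM
Compound 2 `COc1ncc(-c2ccc3c(c2)NC(=O)CO3)cc1NS(=O)(=O)c1ccc(F)cc1` gives 7110 nM
Compound 3 `COc1ncc(-c2ccc3c(c2)N(c2ccccc2)C(=O)CO3)cc1NS(=O)(=O)c1ccc(F)cc1` gives 1530 nM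

Compound 3 has the lowest number of the three, and its gaps to both others lie beyond the scatter. Compound 4 `COc1ncc(-c2ccc3c(c2)N(c2ccc(Cl)cc2)C(=O)CO3)cc1NS(=O)(=O)c1ccc(F)cc1` carries chloro in place of hydrogen on an aromatic carbon, so that phenyl becomes 4-chlorophenyl.

Among the measured compounds shown here, no chloro compound has been measured. The nearest evidence is compound 1, which has methyl on that carbon, and the data show a 3.0-fold lower number from compound 1 to compound 3 (0.48 log units; beyond the scatter) when methyl gives way to hydrogen. Adding phenyl itself gave a 4.6-fold lower number from compound 2 to compound 3 (0.67 log units; beyond the scatter) while 4-methylphenyl gave a 1.5-fold higher number from compound 1 to compound 2 (0.18 log units; within the scatter) so the gain seen with phenyl was not kept with methyl on the ring. On this single precedent a modest move to a higher number is expected, and the expected step is a 2.0-fold higher number from compound 3 to compound 4 (0.29 log units; within the scatter) in this assay as estimated here. Compound 4 is expected at 3000 nM with an estimated range from 1300 nM to 6500 nM on this read-out.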

Compound 4, half-maximal inhibitory concentration: 4830 nM
Beside the measured number, compound 4's estimate is 1.6-fold (0.21 log units) below it; measured number inside the range.
By their numbers in this assay, from the lowest: compound 3; then compounds 1, 4 and 2 (each within the scatter of the next).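

In this assay, chloro on the aromatic carbon para to a large group gives a 3.2-fold higher number from compound 3 to compound 4 (0.50 log units; beyond the scatter) and so loses the advantage of the unsubstituted phenyl; chloro in place of methyl gives a 1.0-fold higher number from compound 1 to compound 4 (0.02 log units; within the scatter), so the data do not separate these two substituents at this position. With 4-chlorophenyl in place of hydrogen on the ring amide nitrogen, the result is a 1.5-fold lower number from compound 2 to compound 4 (0.17 log units; within the scatter), so compound 4, like compound 1, keeps no gain beyond the scatter over the unsubstituted nitrogen of compound 2. Nothing given here accounts for this loss.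

The compounds shown leave open whether a fluoro, a methoxy or an amine at this position would read with compound 3 or with compounds 1 and 4. They also leave open whether chloro elsewhere on the same phenyl would carry the same penalty.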